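The source may hold more compounds than are shown below. What is called first, only, known or untested is meant among the compounds shown, and "the series" means these compounds.

Measured so far in a functional assay on HepG2 cells (Homo sapiens) for inhibition, read by MTT assay, with a stated time of 72 h; on this read-out higher numbers stand for weaker inhibition and lower numbers for stronger inhibition: compound 1 `C#CCSc1nc(Nc2ccccc2)c2ccncc2n1` gives 29400 nM; compound 2 `C#CCSc1nc(Nc2ccccc2Cl)c2ccncc2n1` gives 17200 nM; compound 3 `C#CCSc1nc(Nc2ccc(Cl)cc2)c2ccncc2n1` gives 36700 nM.

Compound 3 stands at the highest of the three numbers in this assay; its gap to compound 1 is within the scatter, while a 2.1-fold higher number from compound 2 to compound 3 (0.33 log units; beyond the scatter) lies beyond it. Compound 4 `C#CCSc1nc(Nc2ccc(Cl)cc2Cl)c2ccncc2n1` differs from compound 3 by chloro in place of hydrogen on an aromatic carbon. Among the measured compounds shown here, two measured steps bear on it: a 1.7-fold lower number from compound 1 to compound 2 (0.23 log units; within the scatter), the same kind of chloro entering ortho to the large group, and a 1.2-fold higher number from compound 1 to compound 3 (0.10 log units; within the scatter). Both lie within the scatter, so for compound 4 no step beyond the scatter is expected in this assay, if anything a slightly lower number, expected as a 1.4-fold lower number from compound 3 to compound 4 (0.15 log units; within the scatter). Compound 4 is therefore estimated at 26000 nM, with a range of 12000 nM to 60000 nM.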

Compound 4, half-maximal inhibitory concentration: 11000 nM
Estimate against measurement, compound 4: 2.4-fold (0.37 log units) above, and the stated range ends above it.
By their numbers in this assay, from the lowest: compounds 4, 2, 1 and 3 (each within the scatter of the next, the first and the last beyond it).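

In this assay, chloro ortho to a large group, set on compound 3, gives a 3.3-fold lower number from compound 3 to compound 4 (0.52 log units; beyond the scatter), so this change at this position now shows a step beyond the scatter, though it cannot be separated from the smaller step on the core of compound 1: the same change on two cores in this assay, a 1.7-fold lower number (0.23 log units; within the scatter) from compound 1 to compound 2 and a 3.3-fold lower number (0.52 log units; beyond the scatter) from compound 3 to compound 4, 2.0-fold (0.29 log units) apart, within the scatter of two such steps. Chloro entering compound 2 gives a 1.6-fold lower number from compound 2 to compound 4 (0.19 log units; within the scatter), which stays within the scatter, as does the matching step on compound 1: the same change on two cores in this assay, a 1.2-fold higher number (0.10 log units; within the scatter) from compound 1 to compound 3 and a 1.6-fold lower number (0.19 log units; within the scatter) from compound 2 to compound 4, 2.0-fold (0.29 log units) apart, within the scatter of two such steps. Still open, going by these compounds, is whether a group other than chloro at this position, such as methoxy, an amine or a carboxylic acid, moves the number as far.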